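This account rests on a few compounds, and the source may have more. Where it says the series, first, only, none or still open, it means among the compounds named here.

Working notes on the series. Compound 1 `CCCCN(CC)c1cc(C)nc2c1NC(=O)CN2c1ccc(C)cc1Cl` and compound 2 `CCCCN(CC)c1cc(C)nc2c1NC(=O)CN2c1ccc(Br)cc1CC` share one core and differ only in the aryl group carried by the ring nitrogen. In an assay on HEK-293T cells for displacement of a labelled ligand from corticotropin-releasing factor receptor 2 (Homo sapiens), read by scintillation counting, with a stated time of 2 h, tested at 1 uM (on this read-out lower numbers stand for less inhibition and higher numbers for more inhibition at the one concentration tested (going by the name of the read-out)), compound 1 stands as "not determined" (no result reported), so no number is given for it. In this assay, among the compounds with values here, compound 2 gives 2.1%; this is the only number in the set, so there is no position to rank, and the figure sits at the low end of the read-out, meaning compound 2 displaces little of the labelled ligand at the one concentration tested.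

Compound 3 `CCCCN(CC)c1cc(C)nc2c1NC(=O)CN2c1ccc(Cl)cc1Cl` is the next entry. Against compound 2 the change is 2,4-dichlorophenyl in place of 4-bromo-2-ethylphenyl on a nitrogen on an aromatic ring in a ring. Within the data shown here, no step between two measured compounds exists in this set, so the data give no indication of how an exchange at this ring nitrogen moves the read-out; the only anchor is the low value of compound 2. The expected step is a number 2.9 percentage points higher from compound 2 to compound 3 (within the scatter), that is, none beyond the scatter, with compound 3 expected to remain near the floor of the read-out. Compound 3 is accordingly estimated at 5% in this assay, within a range from -8% to 25%.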

Compound 3, a percentage reported as inhibition, at one concentration (the size of the read-out at that concentration, not a potency): 0.9%
Compound 3: middle estimate off by 4.1 percentage points, on the high side; low and high end bracket the measured number.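

In this assay this ring nitrogen now has its first readable step: 2,4-dichlorophenyl in place of 4-bromo-2-ethylphenyl gives a number 1.2 percentage points lower from compound 2 to compound 3 (within the scatter). The exchange alters two substituents of the aryl group together, yet both compounds stay at the low end of the read-out, so this change brings no gain in displacement of the labelled ligand at the one concentration tested. No measurement shown bears on why the two aryl groups read alike.

From the compounds shown here alone, with compound 1 carrying no number and the other two values close to the floor, it remains open whether any aryl group at this ring nitrogen can raise the read-out in this assay. Also open, going by these compounds, is how a pyridine ring in place of the phenyl ring, a phenyl ring bearing a methoxy group or a carboxylic acid, or a longer chain on the amine of the shared core would read.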